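Ester to hydrazide on an anti-inflammatory oxo-core

The compounds below may be only part of what the source reports. "The series", "measured", "known", "first", "only" and "open" are said of these compounds alone.

Compound 1 `CCOC(=O)C(=O)Nc1cccccc1=O` is the reference point of this small set. In a functional assay on the whole organism (strain Sprague-Dawley CD) for inhibition, with Rattus norvegicus as the target, read by paw edema, at a dose of 30 mg/kg by the oral route (on this read-out higher numbers stand for a stronger effect at the one dose given and lower numbers for a weaker effect), compound 1 gives 79%, the highest of the three numbers measured. Compound 2 `CCOC(=O)C(=O)Nc1c(C)ccccc1=O` carries a methyl in place of hydrogen on an aromatic carbon and gives 4%, a step of a number 75 percentage points lower from compound 1 to compound 2 (beyond the scatter). Compound 3 `CCOC(=O)C(=O)Nc1cccc(OC)cc1=O` carries a methoxy in place of hydrogen on an aromatic carbon and gives 45%, a step of a number 34 percentage points lower from compound 1 to compound 3 (beyond the scatter).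

Compound 4 `NNC(=O)C(=O)Nc1cccccc1=O` has not been measured. It differs from compound 1 by aminoamino in place of ethoxy on a carbonyl carbon. Both measured steps alter the ring of the shared core, whereas this change sits on the side chain, so neither step bears directly on it; the two ring changes only show that the number can fall steeply. Among the compounds with values here, with no step at the carbonyl carbon to lean on, the expectation for compound 4 is uncertain, and a step of a number 24 percentage points lower from compound 1 to compound 4 (beyond the scatter) is estimated. Compound 4 is therefore expected to give about 55%, within a range from 15% to 85%.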

Compound 4, a percentage reported as inhibition, in the whole organism at one dose (the size of the read-out at that dose, not a potency): 41%
Estimate against measurement, compound 4: 14 percentage points above; the measured number falls inside the stated range.
By their numbers in this assay, from the lowest: compound 2; then compounds 4 and 3 (each within the scatter of the next); then compound 1.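

Replacing ethoxy with aminoamino on the carbonyl carbon gives a number 38 percentage points lower from compound 1 to compound 4 (beyond the scatter) in this assay, so the side chain, and not only the ring of the shared core, can move this number. The change removes a group with 3 heavy atoms and 0 hydrogen-bond donors and brings in one with 2 heavy atoms and 2 hydrogen-bond donors, yet compound 4 still gives 41% at the one dose. Nothing available explains the drop or ties it to either of these differences.

From the compounds shown here alone, it remains open whether an amine, a carboxylic acid or a longer chain at this carbonyl carbon would stay closer to compound 1 at 79%. Also open, going by these compounds, is how aminoamino would behave together with a methyl or methoxy on the ring.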